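The source may report more compounds than this note shows. Statements on the series, on what has been measured and on what is new or still open speak of the compounds shown alone.

Measured so far in an assay on isolated protein for displacement of a labelled ligand from Apoptosis regulator Bcl-2 (Homo sapiens), read by fluorescence polarization; a higher number here means a weaker inhibitor, a lower number a stronger inhibitor:
compound 1, `COC1(Cc2ccccc2C)CCN(c2ccc(C(=O)NS(=O)(=O)c3ccc(N[C@H](CCN(C)C)CSc4ccccc4)c([N+](=O)[O-])c3)cc2)CC1`, gives 1.4 nM
compound 2, `CN(C)CC[C@H](CSc1ccccc1)Nc1ccc(S(=O)(=O)NC(=O)c2ccc(N3CCC(=Cc4ccc(F)cc4)CC3)cc2)cc1[N+](=O)[O-]`, gives 3.4 nM
compound 3, `CN(C)CC[C@H](CSc1ccccc1)Nc1ccc(S(=O)(=O)NC(=O)c2ccc(N3CCC(=Cc4ccccc4C(F)(F)F)CC3)cc2)cc1[N+](=O)[O-]`, gives 2 nM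

Compound 3 holds the second of the three numbers; its gap to compound 1 and its gap to compound 2 both fall within the scatter, so the three values read as one level. Among the compounds with values here, the only change made so far at the same place is a 1.7-fold lower number from compound 2 to compound 3 (0.23 log units; within the scatter), which stayed within the scatter.

Compound 4, `CN(C)CC[C@H](CSc1ccccc1)Nc1ccc(S(=O)(=O)NC(=O)c2ccc(N3CCC(=Cc4ccccc4C#N)CC3)cc2)cc1[N+](=O)[O-]`, differs from compound 3 in one place: cyano in place of trifluoromethyl on an aromatic carbon. Within the data shown here, no measured pair shows this particular exchange; the nearest evidence is the step from compound 2 to compound 3, where a change of the group on that ring left the number within the scatter. On that basis no step beyond the scatter is expected in this assay, and the expected step is a 1.3-fold higher number from compound 3 to compound 4 (0.10 log units; within the scatter). For compound 4 the estimated value in this assay is 2.5 nM, with a range from 1 nM to 6 nM.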

Compound 4, inhibition constant: 13 nM
Compound 4: middle estimate off by 5.2-fold (0.72 log units), on the low side; the measured number lies above the stated range.
By their numbers in this assay, from the lowest: compounds 1, 3 and 2 (each within the scatter of the next, the first and the last beyond it); then compound 4.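

In this assay this position is not indifferent to the group it carries: cyano in place of trifluoromethyl on the aromatic carbon gives (a 6.5-fold higher number from compound 3 to compound 4 (0.81 log units; beyond the scatter)), a modest step beyond the scatter, whereas the earlier change on this ring gave (a 1.7-fold lower number from compound 2 to compound 3 (0.23 log units; within the scatter)), which stayed within it. The 2-cyanophenyl group also stands apart from 4-fluorophenyl, with (a 3.8-fold higher number from compound 2 to compound 4 (0.58 log units; beyond the scatter)) again beyond the scatter, so compound 4 is separated from both of its neighbours at this position. Nothing at hand accounts for this step.

The compounds shown hold cyano at one place on the ring only, so the effect of the group cannot be separated from that of its place. From the compounds shown here alone, how an amine or a carboxylic acid on the same aromatic carbon would read in this assay remains open.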